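The source may report more compounds than this note shows. Statements on the series, on what has been measured and on what is new or still open speak of the compounds shown alone.

Series notes, solubility.

Three compounds share a core and differ in the saturated ring and its nitrogen substituent. Compound 1 `NC(=O)c1ccc2[nH]c(-c3ccc(OCCC4CCCCN4Cc4ccc(Cl)cc4)cc3)nc2c1` gives 115000 nM in a physicochemical assay for solubility, with a stated time of 3 days, at pH 7; on this read-out higher numbers stand for higher solubility and lower numbers for lower solubility. Compound 3 `NC(=O)c1ccc2[nH]c(-c3ccc(OCCC4CCCCN4C(=O)c4ccccc4)cc3)nc2c1` carries the change benzoyl in place of 4-chlorobenzyl on an amine nitrogen in a ring and in this assay compound 3 gives 18000 nM, so the step is a 6.4-fold lower number from compound 1 to compound 3 (0.81 log units; beyond the scatter). Compound 2 `NC(=O)c1ccc2[nH]c(-c3ccc(OCCC4CCN(Cc5ccc(Cl)cc5)CC4)cc3)nc2c1` has the same atoms as compound 1 joined differently; the difference between the two cores is not broken down here. In this assay compound 2 gives 2000 nM, the lowest of the three numbers, beyond the scatter from both others.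

Compound 4 `NC(=O)c1ccc2[nH]c(-c3ccc(OCCC4CCN(C(=O)c5ccccc5)CC4)cc3)nc2c1` is not yet measured. It differs from compound 2 by benzoyl in place of 4-chlorobenzyl on an amine nitrogen in a ring, the same kind of change as that from compound 1 to compound 3, though the place is not the same: in compound 3 the amine nitrogen is next to the ring atom that bears a large group, in compound 4 it is three ring bonds from that ring atom.

Going by the values given here, the expectation for compound 4 rests on the only comparable step, that from compound 1 to compound 3, which was a 6.4-fold lower number from compound 1 to compound 3 (0.81 log units; beyond the scatter). The same direction is expected for compound 4, with the step estimated as a 4.0-fold lower number from compound 2 to compound 4 (0.60 log units; beyond the scatter), the range kept wide since the starting number for compound 2 is already low and the place differs. Compound 4 is thus estimated at 500 nM in this assay, between 100 nM and 3000 nM.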

Compound 4, solubility: 3000 nM
Estimate against measurement, compound 4: 6.0-fold (0.78 log units) below; the range from low to high includes it.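

In this assay, benzoyl in place of 4-chlorobenzyl on the ring nitrogen gives a 1.5-fold higher number from compound 2 to compound 4 (0.18 log units; within the scatter), whereas on the core of compound 1 the same kind of change gave a 6.4-fold lower number from compound 1 to compound 3 (0.81 log units; beyond the scatter). The step therefore did not carry from one core to the other: it lies beyond the scatter on the core of compound 1 and within it on the core of compound 2, so in this series its size on one core cannot be taken as a guide to its size on the other. This rests on a single pair per core and shows nothing about other nitrogen substituents, and nothing in the data accounts for the contrast between the two pairs.

The change removes a chlorine and brings in a carbonyl at once, so the two parts remain unseparated; a plain benzyl group or a 4-chlorobenzoyl group on the same nitrogen in both cores would be needed to tell them apart. Also open, on these data alone, is whether the contrast between the cores holds for substituents of another kind, such as an acetyl group or a benzoyl group carrying a carboxylic acid.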